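A few compounds are considered here, and "the series" means these few. Any claim that something is new, unique, unknown or untested is made for them only; others in the source may bear on it.

Of the compounds shown here, three have been measured in a functional assay on HEK293 cells for agonist activity at Glucose-dependent insulinotropic receptor (Homo sapiens), read by cAMP accumulation, with a stated time of 60 min; a lower number here means that less compound is needed, a higher number that more compound is needed for the effect. Compound 1 `CCCS(=O)(=O)N1CC=C(c2ccc3c(c2)CC(C2CCN(Cc4ccccc4)CC2)O3)CC1` gives 521 nM, compound 2 `CCCS(=O)(=O)N1CC=C(c2ccc3c(c2)CC(C2CCN(S(=O)(=O)CCC)CC2)O3)CC1` gives 1000 nM, and compound 3 `CCCS(=O)(=O)N1CC=C(c2ccc3c(c2)CC(C2CCN(c4ncc(C5CC5)cn4)CC2)O3)CC1` gives 67 nM, the lowest of the three numbers. The steps of a 7.8-fold lower number from compound 1 to compound 3 (0.89 log units; beyond the scatter) and a 15-fold lower number from compound 2 to compound 3 (1.17 log units; beyond the scatter) lie beyond the scatter, whereas a 1.9-fold higher number from compound 1 to compound 2 (0.28 log units; within the scatter) does not. Compound 4 `CCCc1cnc(N2CCC(C3Cc4cc(C5=CCN(S(=O)(=O)CCC)CC5)ccc4O3)CC2)nc1` differs from compound 3 by propyl in place of cyclopropyl on an aromatic carbon. Among the measured compounds shown here, no measured step bears on this position: all three exchange the group on the amine nitrogen in a ring of the shared core, and the pyrimidine substituent is untouched in every measured pair. The expected step is therefore a 1.0-fold lower number from compound 3 to compound 4 (0.01 log units; within the scatter), none beyond the scatter. Compound 4 is estimated at 65 nM in this assay, with a range from 20 nM to 210 nM.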

Compound 4, half-maximal effective concentration: 82 nM
Compound 4: the middle estimate sits 1.3-fold (0.10 log units) below what was measured, within the range that was stated.
By their numbers in this assay, from the lowest: compounds 3 and 4 (each within the scatter of the next); then compounds 1 and 2 (each within the scatter of the next).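

In this assay, replacing cyclopropyl with propyl on the aromatic carbon gives a 1.2-fold higher number from compound 3 to compound 4 (0.09 log units; within the scatter), so in this pair the three-membered ring is not needed to keep the number low. The 5-propylpyrimidin-2-yl group also stands well apart from the other nitrogen substituents, with a 12-fold lower number from compound 2 to compound 4 (1.09 log units; beyond the scatter) and a 6.4-fold lower number from compound 1 to compound 4 (0.80 log units; beyond the scatter). Nothing available offers an explanation for this result.

From the compounds shown here alone, whether a longer chain, a methoxy group or an amine at this position would leave the number unchanged remains open.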